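The source may report more compounds than this note shows. Statements on the series, on what has been measured and on what is new or still open speak of the compounds shown alone.

Measured compounds: compound 1 `COc1cc(N(C)CCN(C)C)c(NC(=O)/C=C\C(C)C)cc1Nc1nccc(-c2cn(C)c3ccccc23)n1` with 4390 nM; compound 2 `C=C(Cl)C(=O)Nc1cc(Nc2nc(C)cc(-c3cn(C)c4ccccc34)n2)c(OC)cc1N(C)CCN(C)C` with 3640 nM; compound 3 `CC/C=C\C(=O)Nc1cc(Nc2nc(C)cc(-c3cn(C)c4ccccc34)n2)c(OC)cc1N(C)CCN(C)C` with 2050 nM, all in a functional assay on HepG2 cells (Homo sapiens) for antiproliferative activity, read by MTT assay, with a stated time of 72 h; a lower number here means a stronger inhibitor, a higher number a weaker inhibitor.

Compound 3 carries the lowest of the three numbers; compound 2 sits within the scatter of it, compound 1 beyond it. Compound 4 `COc1cc(N(C)CCN(C)C)c(NC(=O)/C=C\C(C)C)cc1Nc1nc(C)cc(-c2cn(C)c3ccccc23)n1` differs from compound 3 by methyl in place of hydrogen on a saturated chain carbon bound to a double-bonded chain carbon and a saturated chain carbon. Within the data shown here, no measured step covers this change. Among the measured compounds shown here, the one step measured, a 1.8-fold lower number from compound 2 to compound 3 (0.25 log units; within the scatter), altered the chain on the carbonyl and stayed within the scatter. Compound 1 carries the same 3-methylbut-1-en-1-yl chain as compound 4 but differs from it elsewhere, so its value bears only loosely. Expectation: compound 4 is estimated to show a 1.3-fold higher number from compound 3 to compound 4 (0.10 log units; within the scatter), i.e. no step beyond the scatter. The estimate for compound 4 is 2600 nM, range 1000 nM to 6500 nM.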

Compound 4, half-maximal inhibitory concentration: 3550 nM
The estimate for compound 4 lay 1.4-fold (0.14 log units) below the measured number; measured number inside the range.
By their numbers in this assay, from the lowest: compounds 3, 4, 2 and 1 (each within the scatter of the next, the first and the last beyond it).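

In this assay methyl in place of hydrogen on this saturated chain carbon gives a 1.7-fold higher number from compound 3 to compound 4 (0.24 log units; within the scatter) and so leaves the number unresolved from that of the but-1-en-1-yl amide. Placing 3-methylbut-1-en-1-yl on the carbonyl carbon in place of 1-chloroethenyl gives a 1.0-fold lower number from compound 2 to compound 4 (0.01 log units; within the scatter) while methyl in place of hydrogen on an aromatic carbon gives a 1.2-fold lower number from compound 1 to compound 4 (0.09 log units; within the scatter) so none of the three new steps separates compound 4 from its neighbours. No measured evidence on these steps is available. Open, as far as these compounds go, is whether a longer chain or an amine at this saturated chain carbon would move the number beyond the scatter.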